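The source may report more compounds than this note shows. Statements on the series, on what has been measured and on what is new or still open speak of the compounds shown alone.

Working notes on the series, read in a physicochemical assay for solubility, at pH 2; on this read-out lower numbers stand for lower solubility and higher numbers for higher solubility. Compound 1 `OCCNc1nc(NCc2ccco2)c2ccccc2n1` reads >= 30000 nM, which is a limit of the assay and not a number. Compound 2 `CSCCNc1nc(NC(C)C)nc2ccccc12` reads >= 30000 nM, again a limit. Compound 3 `CCOC(=O)CNc1nc(NC(C)C)nc2ccccc12` reads >= 30000 nM, also a limit, so it has no number of its own. The three compounds stand together: the limit of >= 30000 nM in this assay, at which 3 of the 3 values shown sit.

Going by the values given here, the one measured step is a step that the two limits leave unreadable from compound 2 to compound 3, so no size can be taken from it.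

Compound 4 `CC(C)Nc1nc(N(C)C)c2ccccc2n1`, not yet measured, has dimethylamino in place of ((ethoxycarbonyl)methyl)amino on an aromatic carbon, next to the ring nitrogen and meta to an isopropylamino group (dimethylamino in place of ((ethoxycarbonyl)methyl)amino on an aromatic carbon). Among the compounds with values here, no measured step covers this exchange, and the only guide is that compound 1, compound 2 and compound 3 carry different groups and show no readable difference.

For compound 3 the reading stays the limit >= 30000 nM, and on that basis no step beyond the scatter is expected in this assay, in either direction. The expected step is a number no higher from compound 3 to compound 4 (the limit leaves the size open). Compound 4 is estimated at 30000 nM, with an expected range of 15000 nM to 60000 nM, and the read-out is likely to be only a limit again.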

Compound 4, solubility: >= 30000 nM
Compound 4 ended at the assay's limit; the forecaster's own chance of this, stated with the estimate: 85%; the middle value lies on the limit itself.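

No new step can be read: compound 4 against compound 3 and against compound 2 joins a limit to a limit, so in this assay the size of both steps stays unreadable. The compounds shown leave open how far each lies from that limit and whether any exchange on the shared core changes the read-out, for all stand together: the limit of >= 30000 nM in this assay, at which 4 of the 4 values shown sit.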